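This account rests on a few compounds, and the source may have more. Where it says the series, first, only, none or still open, it means among the compounds named here.

Two compounds share one core, a five-membered aromatic ring with one nitrogen and one sulfur carrying a carboxymethyl group and a bis(4-fluorophenyl)methyl group. Compound 1 `N#Cc1cc(-c2nc(C(c3ccc(F)cc3)c3ccc(F)cc3)sc2CC(=O)O)ccc1F` gives 57 nM in an in vitro assay on HEK385-7 cells for displacement of a labelled ligand from prostaglandin D2 receptor 2 (Homo sapiens) (on this read-out higher numbers stand for weaker inhibition and lower numbers for stronger inhibition), and compound 2 `O=C(O)Cc1sc(C(c2ccc(F)cc2)c2ccc(F)cc2)nc1-c1cc(F)nc(F)c1` gives 5.4 nM. Compound 2 thus holds the lowest number of the two, since an 11-fold lower number from compound 1 to compound 2 (1.02 log units; beyond the scatter).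

Compound 3 `O=C(O)Cc1sc(C(c2ccc(F)cc2)c2ccc(F)cc2)nc1-c1ccnc(N2CCCC2)c1` arises from compound 2 by a change at the same position: 2-(pyrrolidin-1-yl)pyridin-4-yl in place of 2,6-difluoropyridin-4-yl on an aromatic carbon. The only measured step, the large one from compound 1 to compound 2, concerns a different exchange at that position, so no shown step tests this change directly; the large size of that step shows only that what sits on that carbon can move the number strongly. Without a closer precedent, compound 3 is expected to stay near compound 2, the estimated step being a 2.8-fold higher number from compound 2 to compound 3 (0.44 log units; beyond the scatter). The estimate for compound 3 is 15 nM, within 4 nM to 60 nM.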

Compound 3, half-maximal inhibitory concentration: 230 nM
Estimate against measurement, compound 3: 15-fold (1.19 log units) below; measured number outside the range, above it.
By their numbers in this assay, from the lowest: compound 2; then compound 1; then compound 3.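

The result shows that a pyridin-4-yl group on this carbon does not by itself keep the number low: 2-(pyrrolidin-1-yl)pyridin-4-yl in place of 2,6-difluoropyridin-4-yl gives a 43-fold higher number from compound 2 to compound 3 (1.63 log units; beyond the scatter). The same group also compares poorly with the 3-cyano-4-fluorophenyl group, with a 4.0-fold higher number from compound 1 to compound 3 (0.61 log units; beyond the scatter), so the two pyridin-4-yl compounds fall on opposite sides of compound 1 and what is attached to that ring matters greatly. Nothing available explains why this exchange raises the number so strongly.

The exchange removes both fluorines and adds a pyrrolidine at once, so the compounds shown cannot separate these two changes. A single fluorine on the pyridin-4-yl group, or a smaller dimethylamino group in place of the pyrrolidine, would help to tell them apart.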